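Compound 3: the one stereocentre of compound 2 redrawn

The source may report more compounds than this note shows. Statements on the series, on what has been measured and on what is new or still open speak of the compounds shown alone.

In a physicochemical assay for solubility (on this read-out higher numbers stand for higher solubility and lower numbers for lower solubility), compound 1 `CC(C)(C)OC(=O)N1CC[C@H](C(=O)N2CCC(NS(=O)(=O)c3cc(S(=O)(=O)c4ccccc4)ccc3C(F)(F)F)CC2)C1` gives 25000 nM, and compound 2 `O=C([C@H]1CCNC1)N1CCC(NS(=O)(=O)c2cc(S(=O)(=O)c3ccccc3)ccc2C(F)(F)F)CC1` stands level with it at 25000 nM. Within the data shown here, the only measured step is no change at the digits printed from compound 1 to compound 2 (within the scatter), with hydrogen in place of tert-butoxycarbonyl on an amine nitrogen in a ring. Compound 3 `O=C([C@@H]1CCNC1)N1CCC(NS(=O)(=O)c2cc(S(=O)(=O)c3ccccc3)ccc2C(F)(F)F)CC1` carries the two compounds have the same atoms and bonds and differ only in configuration as drawn: 1 of 1 stereo elements differ; a stereocentre at a saturated ring carbon is drawn S in compound 2 and R in compound 3: a stereocentre at a saturated ring carbon is drawn S in compound 2 and R in compound 3. Among the measured compounds shown here, no measured pair tests configuration, so only that flat step bears on it, and no move beyond the scatter is expected in this assay. The expected step is no change at the digits printed from compound 2 to compound 3 (within the scatter). For compound 3 the estimated value is 25000 nM, with a range of 14000 nM to 40000 nM.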

Compound 3, solubility: 12500 nM
For compound 3 the middle estimate is 2.0-fold (0.30 log units) above the measured one, outside the stated range (below it).
By their numbers in this assay, from the lowest: compounds 3, 1 and 2 (each within the scatter of the next).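

In this assay, among these compounds, the step of a 2.0-fold lower number from compound 2 to compound 3 (0.30 log units; within the scatter) is the first reading on configuration at this saturated ring carbon, and it lies within the scatter. The step of a 2.0-fold lower number from compound 1 to compound 3 (0.30 log units; within the scatter) also lies within the scatter, with the loss of tert-butoxycarbonyl and the redrawn stereocentre taken together. The first of these pairs isolates a single variable: the fact that compounds 2 and 3 differ only in the configuration as drawn

As far as these compounds go, whether a carboxylic acid or a longer chain in place of pyrrolidin-3-yl on the carbonyl carbon would give a step beyond the scatter remains open.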